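Acyl variation on the pyrazole nitrogen of the aminopyrazole series

The compounds below may be only part of what the source reports. "The series", "measured", "known", "first", "only" and "open" are said of these compounds alone.

Three compounds of this series have numbers in an assay on Sf9 cells for inhibition of mitogen-activated protein kinase kinase kinase 14 (Homo sapiens), read by ADP-Glo, with a stated time of 60 min; a higher number here means a weaker inhibitor, a lower number a stronger inhibitor. Compound 1 `Cc1cccc(-c2c(N)n[nH]c2C)c1`, which carries no group on the ring nitrogen, returns only a limit in this assay, > 100000 nM, at which (the limit of > 100000 nM in this assay, at which 1 of the 3 values shown sits). Compound 2 `CC(=O)n1nc(C)c(-c2ccc(Cl)c(Cl)c2)c1N` gives 8400 nM in this assay. Compound 3 `Cc1nn(C(=O)C2CCCCC2)c(N)c1-c1ccc(Cl)c(Cl)c1` gives 3300 nM in this assay, the lowest of the two numbers shown; the measured step between the two is a 2.5-fold lower number from compound 2 to compound 3 (0.41 log units; beyond the scatter). Among the measured compounds shown here, that single step is the only measured change on the carbonyl carbon and it shows a modest gain from a larger acyl substituent.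

Compound 4 `Cc1nn(C(=O)OC(C)(C)C)c(N)c1-c1ccc(Cl)c(Cl)c1` is not yet measured. The change from compound 3 is tert-butoxy in place of cyclohexyl on a carbonyl carbon. For the measured compounds named here, only the step from compound 2 to compound 3 bears on it, and it was modest; the new group is a different kind of substituent on the same carbonyl, so no clear direction follows from it. Compound 4 is therefore expected to land close to compound 3, with a step of a 1.4-fold higher number from compound 3 to compound 4 (0.13 log units; within the scatter) allowed either way. The estimate for compound 4 in this assay is 4500 nM, with a range from 1500 nM to 14000 nM.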

Compound 4, half-maximal inhibitory concentration: > 100000 nM
Compound 4 was reported as a limit; the forecaster's own chance of this, stated with the estimate: 5%; middle value at least 22-fold (1.34 log units) away from the limit.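

In this assay, among the compounds shown here, the carbonyl carbon on the aromatic nitrogen proves far less tolerant of change than the earlier pair suggested: the only earlier change there gave a 2.5-fold lower number from compound 2 to compound 3 (0.41 log units; beyond the scatter), whereas tert-butoxy in place of cyclohexyl gives an at least 30-fold higher number from compound 3 to compound 4 (1.48 log units; beyond the scatter). Tert-butoxy also falls behind methyl on the same carbonyl, with an at least 11-fold higher number from compound 2 to compound 4 (1.07 log units; beyond the scatter), so a larger group here is not a gain in itself, and the modest gain seen with cyclohexyl does not extend to every larger group. Compound 4 gives a limit rather than a number, and it joins the other value at that limit: the limit of > 100000 nM in this assay, at which 2 of the 4 values shown sit.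

The compounds shown do not separate the effect of the oxygen in tert-butoxy from that of its branched carbons; a tert-butyl or cyclohexyloxy group on the same carbonyl would address that. They also leave open where an amine or a longer alkyl chain on this carbonyl would fall, and whether any group there can improve on compound 3 at 3300 nM.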